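Cytotoxicity notes on a dichlorophenyl isoxazole series

This account rests on a few compounds, and the source may have more. Where it says the series, first, only, none or still open, it means among the compounds named here.

Compound 1 `COc1ccc(CNC(=O)c2c([N+](=O)[O-])noc2-c2ccc(Cl)cc2Cl)cc1` is the reference point of the series. In an ADME assay on J774.A1 cells (Mus musculus) for cytotoxicity, read by MTT assay, with a stated time of 48 h (a higher number here means that more compound is tolerated, a lower number that less compound is tolerated), compound 1 gives 80500 nM. Compound 2 `COc1ccc(CNC(=O)c2c([N+](=O)[O-])noc2-c2ccc(Cl)cc2Cl)cc1OC` carries the change methoxy in place of hydrogen on an aromatic carbon and in this assay compound 2 gives 81800 nM; the step of a 1.0-fold higher number from compound 1 to compound 2 (0.01 log units; within the scatter) is within the scatter, so the two values are read as the same.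

Compound 3 `COC(=O)c1c(NCc2ccc(OC)cc2)noc1-c1ccc(Cl)cc1Cl` has a different core; the difference between the two cores is not broken down here. In this assay compound 3 gives 34700 nM, the lowest of the three numbers, beyond the scatter from compound 1 and from compound 2.

Compound 4 `COC(=O)c1c(NCc2ccc(OC)cc2OC)noc1-c1ccc(Cl)cc1Cl` is not yet measured in this assay. It carries the change (methoxy in place of hydrogen on an aromatic carbon), the same kind of change as seen from compound 1 to compound 2, but not the same: in compound 2 the entering methoxy stands ortho to a methoxy group and meta to a large group, whereas in compound 4 it stands ortho to a large group and meta to a methoxy group.

For the measured compounds named here, the expectation for compound 4 rests on the only measured instance of this kind of change, the step of a 1.0-fold higher number from compound 1 to compound 2 (0.01 log units; within the scatter), which lies within the scatter. The step from compound 3 to compound 4 is therefore estimated as a 1.0-fold higher number from compound 3 to compound 4 (0.00 log units; within the scatter). Compound 4 is expected to give about 35000 nM in this assay, with a range from 17000 nM to 70000 nM allowing for the different surroundings of the entering group.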

Compound 4, half-maximal cytotoxic concentration: 32200 nM
Compound 4: the middle estimate sits 1.1-fold (0.04 log units) above what was measured; the range from low to high includes it.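

In this assay, methoxy in place of hydrogen on an aromatic carbon gives a 1.1-fold lower number from compound 3 to compound 4 (0.03 log units; within the scatter), so the two values are read as the same. Set beside the earlier step, the change reads alike on the two cores: the same change on two cores in this assay, a 1.0-fold higher number (0.01 log units; within the scatter) from compound 1 to compound 2 and a 1.1-fold lower number (0.03 log units; within the scatter) from compound 3 to compound 4, 1.1-fold (0.04 log units) apart, within the scatter of two such steps. This shows only that, in these two instances, adding the methoxy leaves the number within the scatter on both cores, with the entering group ortho to a large group and meta to a methoxy group in compound 4 and placed differently in compound 2; it does not show that the same would hold at other places on the ring or on further cores, nor can the place of the group be separated from the core with two steps.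

The compounds shown leave open whether a different group on this ring, such as an amine, a carboxylic acid or a longer alkoxy chain, would shift the number beyond the scatter. Also open, from the compounds shown here alone, is which part of the difference between the core of compound 1 and the core of compound 3 goes with the gap between their values.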